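From 4-methylphenyl to 3-(methoxycarbonyl)phenyl on the shared core

The source may hold more compounds than are shown below. What is called first, only, known or untested is meant among the compounds shown, and "the series" means these compounds.

Measured so far in a functional assay on SK-OV-3 cells (Homo sapiens) for inhibition, read by CCK-8 assay, with a stated time of 70 h; a higher number here means a weaker inhibitor, a lower number a stronger inhibitor:
- compound 1 `COc1ccc(OCCOCCNC2CCCC2)cc1`: 99100 nM
- compound 2 `COc1ccc(COc2ccc(OCCOCCNC3CCCC3)cc2)cc1`: 15700 nM
- compound 3 `Cc1ccc(COc2ccc(OCCOCCNC3CCCC3)cc2)cc1`: 17200 nM

Compound 3, at 17200 nM, holds the second highest of the three numbers, although it cannot be told apart from compound 2 within the scatter. The next compound, compound 4 `COC(=O)c1cccc(COc2ccc(OCCOCCNC3CCCC3)cc2)c1`, differs from it on a saturated chain carbon bound to an oxygen on an aromatic ring: 3-(methoxycarbonyl)phenyl in place of 4-methylphenyl on a saturated chain carbon bound to an oxygen on an aromatic ring.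

Two measured steps show what placing a substituted phenyl group there did, namely a 6.3-fold lower number from compound 1 to compound 2 (0.80 log units; beyond the scatter) and a 5.8-fold lower number from compound 1 to compound 3 (0.76 log units; beyond the scatter), both modest. The closest guide is the swap of methoxy for methyl on that ring, a 1.1-fold higher number from compound 2 to compound 3 (0.04 log units; within the scatter), which stays within the scatter. Among the measured compounds shown here, that is only one swap between two 4-substituted groups, and the data hold no 3-substituted group, so the uncertainty is wide.

The expected result is a 1.0-fold higher number from compound 3 to compound 4 (0.02 log units; within the scatter), which means no change beyond the scatter. For compound 4 the estimated value in this assay is 18000 nM, with an expected range from 8000 nM to 40000 nM.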

Compound 4, half-maximal inhibitory concentration: 45500 nM
Compound 4: middle estimate off by 2.5-fold (0.40 log units), on the low side; measured number outside the range, above it.
By their numbers in this assay, from the lowest: compounds 2 and 3 (each within the scatter of the next); then compound 4; then compound 1.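

In this assay, this position turns out to be sensitive to which substituted phenyl group it carries: 3-(methoxycarbonyl)phenyl gives a weaker result than either 4-methylphenyl (a 2.6-fold higher number from compound 3 to compound 4 (0.42 log units; beyond the scatter)) or 4-methoxyphenyl (a 2.9-fold higher number from compound 2 to compound 4 (0.46 log units; beyond the scatter)). Even so, a substituted phenyl group there still beats hydrogen, as this third example also shows (a 2.2-fold lower number from compound 1 to compound 4 (0.34 log units; beyond the scatter)). Nothing shown here explains why the ester-bearing group behaves differently.

The change alters both the substituent and its location on the ring, so the compounds shown cannot say which of the two raised the number. A 4-(methoxycarbonyl)phenyl or 3-methylphenyl group would separate those two changes, while a 3-carboxyphenyl group, with a carboxylic acid in place of the ester, remains an open comparison.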